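Swapping ethyl for hydrogen on compound 2

The source may report more compounds than this note shows. Statements on the series, on what has been measured and on what is new or still open speak of the compounds shown alone.

Measured in a functional assay (aorta) with Rattus norvegicus as the target (a higher number here means that more compound is needed for the effect, a lower number that less compound is needed), so far
Compound 1 `COc1ccc(-c2nc(/N=C(\N)NC(C)C)sc2-c2ccc(OC)cc2)cc1` gives 9.1 uM
Compound 2 `CCOC(=O)/C=C/c1nc(-c2ccc(OC)cc2)c(-c2ccc(OC)cc2)s1` gives > 100 uM
Compound 3 `COc1ccc(-c2nc(/C=C/C(=O)O)sc2-c2ccc(OC)cc2)cc1` is not yet measured

For compound 2 the reading > 100 uM is a limit of the assay and not a number. Its place on the scale is the limit of > 100 uM in this assay, at which 1 of the 2 values shown sits, and nothing finer. Compound 3 differs in one place hydrogen in place of ethyl on an oxygen next to a carbonyl group with hydrogen in place of ethyl on an oxygen next to a carbonyl group. For the measured compounds named here, the one measured step of an at least 10-fold higher number from compound 1 to compound 2 (1.04 log units; beyond the scatter) is large, but it exchanges a different group on an aromatic carbon and says little about this change. No step beyond the scatter is therefore expected in this assay in either direction. The expected step of a number no higher from compound 2 to compound 3 (the limit leaves the size open) is only an estimate. For compound 3 the estimated value is 100 uM with an expected range from 30 uM to 300 uM and a fair chance of another limit.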

Compound 3, concentration for half-maximal effect: 55 uM
The estimate for compound 3 lay 1.8-fold (0.26 log units) above the measured number; low and high end bracket the measured number.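

Compound 2 gives only a limit of the assay, not a number: the limit of > 100 uM in this assay, at which 1 of the 3 values shown sits. Hydrogen in place of ethyl on an oxygen next to a carbonyl group brings a measurable reading in this assay, with an at least 1.8-fold lower number from compound 2 to compound 3 (0.25 log units; that floor lies within the scatter), so the true size of this change stays open. The 2-carboxyethenyl group still needs more compound than the group it is set against, with a 6.0-fold higher number from compound 1 to compound 3 (0.78 log units; beyond the scatter).

The compounds shown leave open how an amide in place of the carboxy group, or a longer chain carrying that carboxy group, would read in this assay.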